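The source may hold more compounds than are shown below. What is called first, only, known or untested is meant among the compounds shown, and "the series" means these compounds.

Compound 1 `Cc1cc(OCc2cn(-c3ccc(NS(C)(=O)=O)c(Oc4ccccc4)c3)nn2)ccc1Cl`: 5900 nM
Compound 2 `CS(=O)(=O)Nc1ccc(-n2cc(OCc3ccccc3)nn2)cc1Oc1ccccc1`: 10700 nM
Compound 3 `CS(=O)(=O)Nc1ccc(-n2cc(-c3ccccc3)nn2)cc1Oc1ccccc1`: 14200 nM

All three values come from a functional assay on DU-145 cells (Homo sapiens) for inhibition, read by MTT assay, with a stated time of 48 h; a higher number here means a weaker inhibitor, a lower number a stronger inhibitor. Compound 1 gives the lowest number of the three; its gap to compound 2 is a 1.8-fold higher number from compound 1 to compound 2 (0.26 log units; within the scatter), and its gap to compound 3 is a 2.4-fold higher number from compound 1 to compound 3 (0.38 log units; beyond the scatter). Between compound 2 and compound 3 the step is a 1.3-fold higher number from compound 2 to compound 3 (0.12 log units; within the scatter).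

Compound 4 `CS(=O)(=O)Nc1ccc(-n2cc(COc3ccc4ccccc4c3)nn2)cc1Oc1ccccc1` keeps the core of compound 1 and differs in one place: naphthalen-2-yl in place of 4-chloro-3-methylphenyl on an oxygen on a saturated carbon. Cut one bond further out, the change reads 4-chloro-3-methylphenoxy to (naphthalen-2-yl)oxy, so the oxygen on the saturated carbon stays and only the aryl group on it is exchanged. The measured step that bears on this is a 1.8-fold higher number from compound 1 to compound 2 (0.26 log units; within the scatter), where that same aryl group was exchanged for benzyloxy and the number rose only within the scatter. Within the data shown here, no measured step covers a larger aryl group on that oxygen. For compound 4 the expected step is a 1.2-fold lower number from compound 1 to compound 4 (0.07 log units; within the scatter), none beyond the scatter. The estimate for compound 4 in this assay is 5000 nM, in the range 2500 nM to 11000 nM.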

Compound 4, half-maximal inhibitory concentration: 9100 nM
Estimate against measurement, compound 4: 1.8-fold (0.26 log units) below; measured number inside the range.
By their numbers in this assay, from the lowest: compounds 1, 4, 2 and 3 (each within the scatter of the next, the first and the last beyond it).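

In this assay, exchanging the aryl group on the oxygen on a saturated carbon gives a 1.5-fold higher number from compound 1 to compound 4 (0.19 log units; within the scatter), so a second six-membered aromatic ring of carbon only and the loss of both chlorine and methyl are together accommodated at this position without a step beyond the scatter. Earlier steps replaced the whole (4-chloro-3-methylphenoxy)methyl group, whereas this one keeps the oxygen and its saturated carbon and exchanges only the aryl group. No measurement on hand offers an explanation for this result.

The separate contributions of the chlorine and the methyl cannot be read, since both leave in the same step. Also open, on these data alone, is how an amine or a carboxylic acid on this aryl group, or a longer chain carrying the oxygen, would read in this assay.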